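Swapping the glutamate-like tail for a methyl ester

This account rests on a few compounds, and the source may have more. Where it says the series, first, only, none or still open, it means among the compounds named here.

Among the measured compounds shown here, compound 2 `Nc1nc(N)c(CCCN(Cc2ccc(NC(CCC(=O)O)C(=O)O)cc2)c2cc(F)c([N+](=O)[O-])cc2[N+](=O)[O-])c(O)n1` is the only member of this small set with an actual number: in a functional assay on CCRF-CEM cells (Homo sapiens) for cytotoxicity, in the absence of a further agent (on this read-out lower numbers stand for stronger inhibition and higher numbers for weaker inhibition), compound 2 gives 51000 nM. Compound 1 `Nc1nc(N)c(CCCN(Cc2ccc(NC(CCC(=O)O)C(=O)O)cc2)c2cc(F)c(F)cc2[N+](=O)[O-])c(O)n1` reaches only the limit of > 100000 nM in this assay. Compound 3 `Nc1nc(N)c(CCCN(Cc2ccc(NC(CCC(=O)O)C(=O)O)cc2)c2cc(F)ccc2[N+](=O)[O-])c(O)n1` likewise gives only the limit > 100000 nM in this assay. The two readable steps both concern the nitro-bearing ring: an at least 1.9-fold lower number from compound 1 to compound 2 (0.29 log units; that floor lies within the scatter) and an at least 1.9-fold higher number from compound 2 to compound 3 (0.29 log units; that floor lies within the scatter), each resting on the limit (the limit of > 100000 nM in this assay, at which 2 of the 3 values shown sit).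

Compound 4 `COC(=O)c1ccc(CN(CCCc2c(N)nc(N)nc2O)c2cc(F)c([N+](=O)[O-])cc2[N+](=O)[O-])cc1` changes a different part of the molecule: methoxycarbonyl in place of (1,3-dicarboxypropyl)amino on an aromatic carbon. For the measured compounds named here, none of the measured steps touches this position, so no measured step bears directly on the change, and its direction in this assay cannot be read from the data. The expectation therefore stays close to where compound 2 stands, with wide uncertainty. Compound 4 is expected to give about 80000 nM in this assay, within a range from 15000 nM to 400000 nM. This estimate corresponds to an expected step of a 1.6-fold higher number from compound 2 to compound 4 (0.20 log units; within the scatter), and a limit rather than a number is quite possible.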

Compound 4, half-maximal inhibitory concentration: 4300 nM
The estimate for compound 4 lay 19-fold (1.27 log units) above the measured number, outside the stated range (below it).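

This position matters far more than the earlier ring changes could suggest: in this assay, putting methoxycarbonyl in place of (1,3-dicarboxypropyl)amino, on the aromatic carbon para to a large group, gives a 12-fold lower number from compound 2 to compound 4 (1.07 log units; beyond the scatter), so the tail is a strong lever on the read-out. Among the compounds shown here, this is also the first step with a real number at both ends, whereas each readable earlier step rests on a limit: the limit of > 100000 nM in this assay, at which 2 of the 4 values shown sit. Nothing measured in this set explains why the step is so large.

The compounds shown leave open whether a free carboxylic acid, an amide or a simple amine at this position would behave like methoxycarbonyl. As far as these compounds go, the swap is also seen on only one background, so its size with the ring groups of compound 1 or compound 3 remains unknown.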